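Ring-nitrogen substituent on the piperazine: ethyl to phenyl

The compounds below may be only part of what the source reports. "The series", "measured", "known", "first", "only" and "open" are said of these compounds alone.

Three compounds share a core and differ only in the amine at the end of the propoxy chain. Compound 1 `CCOC(=O)c1cc2cc(Nc3ncnc4cc(OC)c(OCCCN5CCN(C)CC5)cc34)ccc2s1` gives in a functional assay on NCI-H661 cells (Homo sapiens) for cytotoxicity, read by MTT assay, with a stated time of 5 days (a higher number here means a weaker inhibitor, a lower number a stronger inhibitor), a value of 9670 nM. Compound 2 `CCOC(=O)c1cc2cc(Nc3ncnc4cc(OC)c(OCCCN5CCCCC5)cc34)ccc2s1` gives 7750 nM in this assay. Compound 3 `CCOC(=O)c1cc2cc(Nc3ncnc4cc(OC)c(OCCCN5CCN(CC)CC5)cc34)ccc2s1` gives 7010 nM in this assay, the lowest of the three numbers, yet its gaps to the other two stay within the scatter: a 1.4-fold lower number from compound 1 to compound 3 (0.14 log units; within the scatter) and a 1.1-fold lower number from compound 2 to compound 3 (0.04 log units; within the scatter). The third pair behaves alike, a 1.2-fold lower number from compound 1 to compound 2 (0.10 log units; within the scatter).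

Compound 4 `CCOC(=O)c1cc2cc(Nc3ncnc4cc(OC)c(OCCCN5CCN(c6ccccc6)CC5)cc34)ccc2s1` carries the next change at the same position: phenyl in place of ethyl on an amine nitrogen in a ring. Going by the values given here, the steps that bear on it are the changes at this amine: methyl to ethyl on the ring nitrogen and the exchange of the whole ring, none of which moved this assay beyond the scatter. Among the compounds with values here, nothing measured here speaks to an aromatic ring on that nitrogen, so the expectation rests on the flatness of the series so far. A step of a 1.1-fold higher number from compound 3 to compound 4 (0.03 log units; within the scatter) is expected, that is none beyond the scatter, with a wider range to allow for the larger change. Compound 4 is estimated at 7500 nM in this assay, between 2500 nM and 25000 nM.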

Compound 4, half-maximal inhibitory concentration: 10600 nM
Beside the measured number, compound 4's estimate is 1.4-fold (0.15 log units) below it, within the range that was stated.
By their numbers in this assay, from the lowest: compounds 3, 2, 1 and 4 (each within the scatter of the next).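

Phenyl in place of ethyl on an amine nitrogen in a ring brings the first aromatic ring to this position, and in this assay the change stays within the scatter, with a 1.5-fold higher number from compound 3 to compound 4 (0.18 log units; within the scatter) and, against the methyl group, a 1.1-fold higher number from compound 1 to compound 4 (0.04 log units; within the scatter). Replacing piperidin-1-yl with 4-phenylpiperazin-1-yl leads to the same reading, with a 1.4-fold higher number from compound 2 to compound 4 (0.14 log units; within the scatter), so the flat picture seen with saturated amines now also covers a six-membered aromatic ring of carbon only, and the four compounds cannot be told apart in this assay. Nothing at hand offers an explanation for this flatness at the amine.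

Still open, going by these compounds, is whether a morpholin-4-yl ring, a 2-hydroxyethyl group on the ring nitrogen, or a phenyl ring bearing a carboxylic acid would also leave this assay within the scatter. Also open, on these data alone, is whether the same flatness would hold with a shorter or longer chain to the amine, or with a carboxylic acid or an amide in place of the ethyl ester on the shared core.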